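Trading the Amide for an Ester on a CDK8 Inhibitor

The source may report more compounds than this note shows. Statements on the series, on what has been measured and on what is new or still open speak of the compounds shown alone.

Of the compounds shown here, three have been measured in an assay on a protein complex for inhibition of CDK8/Cyclin C (Homo sapiens), with a stated time of 1 h; a lower number here means a stronger inhibitor, a higher number a weaker inhibitor. Compound 1, `NC(=O)/C=C/c1ccncc1-c1ccc2ccccc2c1`, gives 10.5 nM and has the lowest number of the three; its steps to both others are beyond the usual scatter. Compound 2, `Cn1ccc2cc(-c3cnccc3/C=C/C(=O)O)ccc21`, gives 26.8 nM, and compound 3, `O=C(/C=C/c1ccncc1-c1ccc2[nH]ccc2c1)N1CCOCC1`, gives 190 nM. Compounds 2 and 3 differ from compound 1 in more than one place at once, so what sets them apart from compound 1 cannot be tied to any single change.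

The next compound, compound 4, `COC(=O)/C=C/c1ccncc1-c1ccc2ccccc2c1`, is not yet measured. It differs from compound 1 in one place: methoxy in place of amino on a carbonyl carbon. The rest of the molecule, the shared core with its naphthalene-bearing pyridine and the double-bonded chain, is untouched.

Within the data shown here, no measured pair shows this exact change, so the direction has to be an expectation rather than a reading from the data. Replacing the carbamoyl group with a methoxycarbonyl group removes the one hydrogen-bond donor in that part of the molecule, and such swaps in this assay commonly cost some potency. The step from compound 1 to compound 4 is therefore expected to be a modest loss, a 2.9-fold higher number from compound 1 to compound 4 (0.46 log units; beyond the scatter), somewhat beyond the scatter. Compound 4 is estimated at 30 nM, with a plausible range from 10 nM to 100 nM.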

Compound 4, half-maximal inhibitory concentration: 40.6 nM
For compound 4 the middle estimate is 1.4-fold (0.13 log units) below the measured one; low and high end bracket the measured number.
By their numbers in this assay, from the lowest: compound 1; then compounds 2 and 4 (each within the scatter of the next); then compound 3.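

Among these compounds, compound 4 gives the first comparison here that can be tied to a single change. With the rest of compound 1 left as it is, methoxy in place of amino on the carbonyl carbon gives a 3.9-fold higher number from compound 1 to compound 4 (0.59 log units; beyond the scatter) in this assay. The carbamoyl group therefore gives the lower number of the two at this position, but the step is modest, and compound 4, with its methoxycarbonyl group, still reads 40.6 nM. No separate measurement bears on why the number rises, so this pair gives the size and direction of the step but no reason for it.

As far as these compounds go, whether a methylamino or an ethoxy group on the same carbonyl carbon would land nearer compound 1 or compound 4 remains open, as does the effect of a nitrile in place of the whole carbamoyl group. Also open, from the compounds shown here alone, is whether the same swap from amino to methoxy would give a step of similar size on the core of compound 3.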